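A Longer Hydroxylated Ester Chain on a Shared Glycoside Core

The source may hold more compounds than are shown below. What is called first, only, known or untested is meant among the compounds shown, and "the series" means these compounds.

Compound 1 `CCCCC[C@H](O)CCCCCCCC(=O)O[C@H]1[C@H](O[C@H]2C(O)O[C@H](COC(C)=O)[C@@H](O)[C@@H]2O)O[C@@H](C)[C@@H](OC(=O)[C@H](C)[C@@H](C)O)[C@H]1O[C@@H]1O[C@@H](C)[C@H](O)[C@@H](O)[C@H]1O` is one of two measured members of this series. In a functional assay on KB/VCR cells (Homo sapiens) for cytotoxicity, read by sulforhodamine B assay, with a stated time of 72 h, tested at 25 uM (a lower number here means less inhibition, a higher number more inhibition at the concentration tested (going by the name of the read-out)), compound 1 gives 0.85%, and it stands together with compound 2 `CCC[C@H](O)CCCCCCCCCC(=O)O[C@H]1[C@H](O[C@H]2C(O)O[C@H](CO)[C@@H](O)[C@@H]2O)O[C@@H](C)[C@@H](OC(=O)[C@H](C)[C@@H](C)O)[C@H]1O[C@@H]1O[C@@H](C)[C@H](O)[C@@H](O)[C@H]1O`, which in this assay gives 1.64%, a gap that lies within the usual scatter. Compound 3 `CCC[C@H](O)CCCCCCCCCCCC(=O)O[C@H]1[C@H](O[C@H]2C(O)O[C@H](COC(C)=O)[C@@H](O)[C@@H]2O)O[C@@H](C)[C@@H](OC(=O)[C@H](C)[C@@H](C)O)[C@H]1O[C@@H]1O[C@@H](C)[C@H](O)[C@@H](O)[C@H]1O` differs from compound 1 by one change: 5-hydroxyoctyl in place of 1-hydroxyhexyl on a saturated chain carbon, seven bonds along the chain from a carbonyl carbon. Among the measured compounds shown here, with no step between measured compounds available, the expected step in this assay is none beyond the scatter, a number 0.7 percentage points higher from compound 1 to compound 3 (within the scatter). Compound 3 is therefore estimated at 1.5%, expected between 0% and 10%.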

Compound 3, a percentage reported as inhibition, at one concentration (the size of the read-out at that concentration, not a potency): -0.47%
For compound 3 the middle estimate is 2 percentage points above the measured one; measured number below the stated range.
By their numbers in this assay, from the lowest: compounds 3, 1 and 2 (each within the scatter of the next).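

In this assay, putting 5-hydroxyoctyl in place of 1-hydroxyhexyl on a saturated chain carbon, seven bonds along the chain from a carbonyl carbon, gives a number 1.3 percentage points lower from compound 1 to compound 3 (within the scatter). Among the compounds shown here, this is the first comparison that differs in one place, and it shows that this exchange of hydroxylated chains does not move the read-out beyond the usual scatter. No measurement here offers an explanation for this result.

Still open, from the compounds shown here alone, is whether an amine or a carboxylic acid in place of the chain's hydroxyl would change the reading. A much longer chain at this position is also untested by these compounds.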